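The compounds below may be only part of what the source reports. "The series", "measured", "known", "first", "only" and "open" are said of these compounds alone.

Measured so far:
- compound 1, `c1ccc2c(NC3CCCCCC3)nc(N3CCC(N4CCCC4)CC3)nc2c1`, in an in vitro assay on B300-19 cells for displacement of a labelled ligand from C-C chemokine receptor type 4 (Homo sapiens), tested at 1 uM (a lower number here means less inhibition, a higher number more inhibition at the concentration tested (going by the name of the read-out)), gives 0%.
- compound 2, `COc1cc2nc(N3CCC(N4CCCC4)CC3)nc(N(C)C)c2cc1OC`, in this assay gives < 0%, which is a limit of the assay rather than a number.

Compound 1 shows no measurable inhibition at the concentration tested. Compound 2 stands at the limit of this assay, described by the limit of < 0% in this assay, at which 1 of the 2 values shown sits, so only a limit is known for it and not a number. The step to compound 3, `COc1cc2nc(N3CCC(N4CCCC4)CC3)nc(NCc3ccccc3)c2cc1OC`, changes one place: benzylamino in place of dimethylamino on an aromatic carbon. For the measured compounds named here, no measured pair carrying this change exists among the compounds above, and both measured compounds sit at zero or at the limit under it. The step from compound 2 to compound 3 in this assay is therefore expected to be small, a modest rise if anything, and possibly not beyond the scatter. The expected step of a number at least 5 percentage points higher from compound 2 to compound 3 (that floor lies within the scatter) reflects this. Compound 3 is estimated at 5%, within a range from -10% to 25%.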

Compound 3, a percentage reported as inhibition, at one concentration (the size of the read-out at that concentration, not a potency): < 0%
Compound 3 ended at the assay's limit; the forecaster's own chance of this, stated with the estimate: 30%; at least 5 percentage points between middle value and limit.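

Compound 2 and compound 3 both stop at a limit of this assay rather than at a number, so the step between them cannot be read: the limit of < 0% in this assay, at which 2 of the 3 values shown sit.

From the compounds shown here alone, whether benzylamino in place of dimethylamino changes inhibition at all remains open.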